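The source may hold more compounds than are shown below. What is called first, only, known or untested is meant among the compounds shown, and "the series" means these compounds.

In a physicochemical assay for lipophilicity, read by HPLC, measured as chromatographic lipophilicity (a higher number here means a more lipophilic compound, a lower number a more polar compound), compound 1 `CCC/N=C1\S/C(=C\c2ccc(C(=O)O)cc2)C(=O)N1c1ccccc1C` gives 1. Compound 2 `CCC/N=C1\S/C(=C\c2ccc(C(=O)OC)c(Cl)c2)C(=O)N1c1ccccc1C` gives > 4.4, and this is a limit of the assay and not a number. Only compound 1 therefore has an exact position on the scale, while compound 2 can be placed only by its limit.

Compound 3 `CCC/N=C1\S/C(=C\c2ccc(C(=O)OC)cc2)C(=O)N1c1ccccc1C` differs from compound 2 in one place: hydrogen in place of chloro on an aromatic carbon, ortho to a methoxycarbonyl group (hydrogen in place of chloro on an aromatic carbon). Among the measured compounds shown here, no measured pair yet shows what this change does in this assay, so the expectation rests on the structural change and on a single starting point. That starting point is compound 2, with its > 4.4, which is again only a limit.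

A small fall in this assay is expected, one that may not clear the usual scatter, and the estimate is a number at least 0.20 log units lower from compound 2 to compound 3 (that floor lies within the scatter). Compound 3 may also turn out to give only a limit. For compound 3 the expected value is 4.2, with an estimated range from 3.8 to 4.6.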

Compound 3, distribution coefficient: > 4.4
Compound 3 ended at the assay's limit; the forecaster's own chance of this, stated with the estimate: 40%; at least 0.20 log units between middle value and limit.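

The new compound shows that the chloro ortho to a methoxycarbonyl group is not needed for a compound to reach the top of the range in this assay, since compound 3 carries only hydrogen on that aromatic carbon and its value is still a limit of the assay, not a number. Among the compounds shown here, it also gives the first readable single change in this set: methyl in place of hydrogen on the oxygen of the carboxylic acid gives a number at least 3.40 log units higher from compound 1 to compound 3 (beyond the scatter). The size of the step for hydrogen in place of chloro cannot be read, as both of its ends are limits and not numbers, and the only measured compound with an exact position is the carboxylic acid: the limit of > 4.4 in this assay, at which 2 of the 3 values shown sit.

From the compounds shown here alone, how far compound 2 and compound 3 lie past that limit stays unknown, so the chloro could have a large effect in this assay, a small one or none. Going by these compounds, it also remains open where a compound with an amine on that same aromatic carbon, ortho to a methoxycarbonyl group, would fall on the scale.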